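One methyl on the chain of compound 2

The source may report more compounds than this note shows. Statements on the series, on what has been measured and on what is new or still open speak of the compounds shown alone.

Compound 1 `COc1ccc(/C=C\c2cc(OC)c(OC)c(OC)c2)cc1NC(=O)CCNC(=O)[C@H](CCCNC(=N)N)NC(=O)[C@H](CCCNC(=N)N)NC(=O)c1ccccc1`: 156 nM
Compound 2 `COc1ccc(/C=C\c2cc(OC)c(OC)c(OC)c2)cc1NC(=O)CN`: 26.9 nM
Compound 3 `COc1ccc(/C=C\c2cc(OC)c(OC)c(OC)c2)cc1NC(=O)CNC(=O)CNC(=O)[C@H](CCCNC(=N)N)NC(=O)[C@H](CCCNC(=N)N)NC(=O)c1ccccc1`: 24 nM

These three compounds share one core and differ in the chain attached to it. In an ADME assay on Huh-7 cells (Homo sapiens) for cytotoxicity, with a stated time of 72 h (on this read-out lower numbers stand for higher toxicity in this test and higher numbers for lower toxicity in this test), compound 2 and compound 3 cannot be told apart within the usual scatter, while compound 1 at 156 nM stands clearly higher than compound 2 on the read-out.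

Compound 4 `COc1ccc(/C=C\c2cc(OC)c(OC)c(OC)c2)cc1NC(=O)[C@H](C)N` has not yet been measured. It departs from compound 2 by one small edit: methyl in place of hydrogen on a saturated chain carbon bound to an amine nitrogen and a carbonyl carbon which places a methyl on a saturated chain carbon bound to an amine nitrogen and a carbonyl carbon, so that aminomethyl becomes 1-aminoethyl.

For the measured compounds named here, no measured pair shows this change directly, so the evidence is indirect. Compound 2 gives 26.9 nM and compound 3 gives 24 nM in spite of their very different chains, although compound 1 goes against this picture. In this assay no shift beyond the scatter is therefore expected, and the estimated change is a 1.1-fold lower number from compound 2 to compound 4 (0.05 log units; within the scatter) in size, with no firm direction. For compound 4 the expected value is 24 nM within an estimated range of 9 nM to 65 nM for this single methyl change.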

Compound 4, half-maximal cytotoxic concentration: 6.03 nM
Beside the measured number, compound 4's estimate is 4.0-fold (0.60 log units) above it; the whole stated range lies above it.
By their numbers in this assay, from the lowest: compound 4; then compounds 3 and 2 (each within the scatter of the next); then compound 1.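

In this assay, the one-place edit that turns aminomethyl into 1-aminoethyl gives a 4.5-fold lower number from compound 2 to compound 4 (0.65 log units; beyond the scatter) and thus marks a lower number, which on this read-out stands for higher toxicity in this test. The earlier compounds shown here differ from one another in whole chains and offer no step at one place, so they could not show that this saturated chain carbon bound to an amine nitrogen and a carbonyl carbon responds to a change as small as one methyl, a single added carbon with no ring, no hydrogen-bond donor or acceptor and no net charge. Nothing measured here accounts for the size or direction of this step, so the result stands as an observation about these two compounds alone.

The compounds shown leave open whether the step belongs to the methyl itself or also depends on the configuration at this carbon, as only one arrangement of the methyl appears, and whether an ethyl, an isopropyl or a second methyl on the same carbon would carry the shift further, stop it or turn it back. They also leave open whether the same methyl has any such effect when the amine is extended into a peptide chain like that of compound 3.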